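Swapping an anilino group for phenoxy on the sulfonyl sulfur

The source may hold more compounds than are shown below. What is called first, only, known or untested is meant among the compounds shown, and "the series" means these compounds.

Compound 3 `CC(C)c1cccc(C(C)C)c1OC(=O)NS(=O)(=O)Nc1ccccc1` is a carbamate built on a shared core, carrying an anilino group on a sulfonyl sulfur. In an assay on liver for inhibition of sterol O-acyltransferase 1 (Rattus norvegicus), using microsomes (on this read-out higher numbers stand for weaker inhibition and lower numbers for stronger inhibition), compound 3 gives 38100 nM. Among the compounds with a single number, compound 3 holds the lower of the two, with compound 1 `CC(C)c1cccc(C(C)C)c1OC(=O)NS(=O)(=O)N1CCCC1` nearest: compound 1 gives 53000 nM, and the difference a 1.4-fold lower number from compound 1 to compound 3 (0.14 log units; within the scatter) is within the scatter. Compound 2 `CCCCN(CCCC)S(=O)(=O)NC(=O)Oc1c(C(C)C)cccc1C(C)C` carries a dibutylamino group in the same place and gives 1900 nM; 1900 nM (2 entries) in this assay.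

Compound 4 `CC(C)c1cccc(C(C)C)c1OC(=O)NS(=O)(=O)Oc1ccccc1` has not been measured. The change is phenoxy in place of anilino on a sulfonyl sulfur, with the replacement occurring on a sulfonyl sulfur whose other neighbour is an amide-type nitrogen. Going by the values given here, the only measured step touching that same sulfonyl sulfur, from compound 1 to compound 3, was within the scatter, so there is no evidence that altering this substituent moves the number far. The step from compound 3 to compound 4 is therefore expected to be small, a 1.1-fold lower number from compound 3 to compound 4 (0.04 log units; within the scatter), with no clear direction. Compound 4 is estimated at 35000 nM, with a range from 10000 nM to 120000 nM.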

Compound 4, half-maximal inhibitory concentration: > 50000 nM
Compound 4 ended at the assay's limit; the forecaster's own chance of this, stated with the estimate: 10%; middle value at least 1.4-fold (0.15 log units) away from the limit.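

Going by these compounds alone, compound 4 is the first compound here with oxygen rather than nitrogen joining the aromatic ring to the sulfonyl sulfur, and this swap brings no sign of stronger inhibition. Its reading is a limit of this assay, not a number: the limit of > 50000 nM in this assay, at which 1 of the 4 values shown sits. The readable result is an at least 1.3-fold higher number from compound 3 to compound 4 (0.11 log units; that floor lies within the scatter), so the change may be small or much larger, while the step from compound 1 to compound 4 cannot be read.

Going by these compounds, how far compound 4 lies past the limit stays open, and so does whether phenoxy truly differs from anilino at this position. Also open, on these data alone, is whether an open-chain amine such as diethylamino or dihexylamino would match compound 2, which gives 1900 nM; 1900 nM (2 entries), or lose that stronger inhibition.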